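The source may report more compounds than this note shows. Statements on the series, on what has been measured and on what is new or still open speak of the compounds shown alone.

The measured compounds:

Compound 1, `Cc1ccc2[nH]c(=O)c(-c3nc4cc(C)c(C)cc4[nH]3)cc2c1`: in an ADME assay on L02 cells (Homo sapiens) for cytotoxicity, read by MTT assay, with a stated time of 48 h (a lower number here means a stronger inhibitor, a higher number a weaker inhibitor), compound 1 gives > 100000 nM, which is a limit of the assay and not a number.
Compound 2, `Cc1ccc2[nH]c(=O)c(-c3nc4cc(Cl)ccc4[nH]3)cc2c1`: here compound 2 gives > 100000 nM, again a limit.
Compound 3, `Cc1cc2nc(-c3cc4ccccc4[nH]c3=O)[nH]c2cc1C`: here compound 3 gives > 100000 nM, also a limit.

Compound 1 and compound 3 differ by one change, (hydrogen in place of methyl on an aromatic carbon). The step it made, a step that the two limits leave unreadable from compound 1 to compound 3, cannot be read, since both values sit at the limit of > 100000 nM in this assay, at which 3 of the 3 values shown sit. The difference between the cores of compound 1 and compound 2 is not broken down here.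

Compound 4, `O=c1[nH]c2ccccc2cc1-c1nc2cc(Cl)ccc2[nH]1`, has not yet been measured in this assay. It arises from compound 2 by hydrogen in place of methyl on an aromatic carbon, the same change as from compound 1 to compound 3, at the same place. Because compound 2 gives > 100000 nM, a limit, compound 4 is expected to stay at the limit as well. The step that the limit leaves unreadable from compound 2 to compound 4 is thus expected to be unreadable. Compound 4 is estimated at 150000 nM, between 60000 nM and 500000 nM.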

Compound 4, half-maximal inhibitory concentration: > 100000 nM
Compound 4 ended at the assay's limit (the forecaster's own chance of this, stated with the estimate: 85%); the middle value lies beyond the limit too.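

No step can be read from compound 2 to compound 4, as both values are limits and not numbers: the limit of > 100000 nM in this assay, at which 4 of the 4 values shown sit.

How far hydrogen in place of methyl moves the value stays open, as does what any of these compounds would give as an actual number.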